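The compounds below may be only part of what the source reports. "The series", "measured", "known", "first", "only" and "open" are said of these compounds alone.

Compound 1 `COc1ccccc1-c1ccccc1O` is a small molecule of two linked rings, and in a functional assay on HT-29 cells (Homo sapiens) for cytotoxicity, read by MTT assay, with a stated time of 3 days (on this read-out lower numbers stand for stronger inhibition and higher numbers for weaker inhibition), compound 1 gives 2.7 ug/mL. Compound 2 `Nc1ccccc1-c1ccccc1O` differs from it in one group only: amino in place of methoxy on an aromatic carbon. In this assay compound 2 gives 44 ug/mL, so the step of a 16-fold higher number from compound 1 to compound 2 (1.21 log units; beyond the scatter) weakens the effect on the cells markedly. Compound 3 `COc1cccc(-c2ccc(O)cc2)c1` holds the same atoms as compound 1 joined in a different pattern; the difference between the two cores is not broken down here. In this assay compound 3 gives 24 ug/mL, which lies beyond the scatter from compound 1 and within the scatter of compound 2.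

Compound 4 `Nc1cccc(-c2ccc(O)cc2)c1` has not yet been measured. It arises from compound 3 by amino in place of methoxy on an aromatic carbon. For the measured compounds named here, this is the same kind of change as the one leading from compound 1 to compound 2, but not the same: in the measured pair the group sits ortho to a group of 7 heavy atoms, whereas in compound 4 it sits meta to a group of 7 heavy atoms. Going by the values given here, only one measured example of this change exists, and it stands on a different core, so its size on the core of compound 3 is uncertain.

From compound 3 to compound 4 a step of a 4.2-fold higher number from compound 3 to compound 4 (0.62 log units; beyond the scatter) is expected, smaller than the measured one. This rests on compound 3 already starting from 24 ug/mL, so that a rise as large as a 16-fold higher number from compound 1 to compound 2 (1.21 log units; beyond the scatter) would land far beyond every number seen so far. Compound 4 is therefore estimated at 100 ug/mL in this assay, with a likely range from 30 ug/mL to 350 ug/mL.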

Compound 4, half-maximal inhibitory concentration: 5.4 ug/mL
For compound 4 the middle estimate is 19-fold (1.27 log units) above the measured one, and the stated range ends above it.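

Putting amino in place of methoxy on the core of compound 3 gives a 4.4-fold lower number from compound 3 to compound 4 (0.65 log units; beyond the scatter) in this assay, so here the change strengthens the effect on the cells, whereas on the core of compound 1 it weakened that effect. The two steps run in opposite directions and lie further apart than repeated measurements would explain, so in this series neither the size nor the direction of this change carries over from one core to the other: the same change on two cores in this assay, a 16-fold higher number (1.21 log units; beyond the scatter) from compound 1 to compound 2 and a 4.4-fold lower number (0.65 log units; beyond the scatter) from compound 3 to compound 4, 72-fold (1.86 log units) apart, beyond the scatter of two such steps

This does not show why the two cores respond differently, since the two pairs differ in how the whole molecule is joined, including where the group sits, and two pairs cannot separate those features or give a rule for a third core.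

The compounds shown leave open whether other groups in the same place, such as a methylamino group, an ethoxy group or a fluorine atom, would also split between the two cores in this way. They also leave open whether an acetamide, built on the amino group of compound 4, would keep the stronger effect seen on that core.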